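The source may report more compounds than this note shows. Statements on the series, on what has been measured and on what is new or still open speak of the compounds shown alone.

Two compounds of a shared core stand at the start of this account. In a functional assay on CHO cells for positive allosteric modulation of muscarinic acetylcholine receptor M5 (Homo sapiens), read by calcium flux (on this read-out higher numbers stand for larger maximal responses and lower numbers for smaller maximal responses), compound 1 `CCN(Cc1ccccc1)C(=O)C1CCN(S(=O)(=O)c2c(C)noc2C)CC1` gives "not determined" (no result reported), so it contributes no number. Compound 2 `CCN(Cc1ccc(F)cc1)C(=O)C1CCN(S(=O)(=O)c2ccc3cn[nH]c3c2)CC1` was tested: in this assay compound 2 gives 55%. Going by the values given here, this is the only number so far, and compound 1 stands beside it without one, so compound 2 cannot be set above or below anything; it simply marks the level from which the next compound is judged.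

Compound 3 `CCN(Cc1cccc(OC)c1)C(=O)C1CCN(S(=O)(=O)c2ccc3cn[nH]c3c2)CC1` differs from compound 2 in one place (3-methoxyphenyl in place of 4-fluorophenyl on a saturated chain carbon bound to an amide-type nitrogen). Among the compounds with values here, no pair of measured compounds differs in a single place, so nothing measured here tells how the maximal response answers such a change. The expectation therefore rests on compound 2 alone, and the estimated step of a number 5 percentage points lower from compound 2 to compound 3 (within the scatter) is not expected to go beyond the usual scatter in either direction. The estimate for compound 3 is 50%, with a range from 30% to 75%.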

Compound 3, largest response reached (reported as percent of maximum), in percent of the reference or control that the assay uses: 85%
For compound 3 the middle estimate is 35 percentage points below the measured one; measured number above the stated range.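

Going by these compounds alone, the first pair that can be read shows that the maximal response in this assay answers a change at this place, on a saturated chain carbon bound to an amide-type nitrogen: 3-methoxyphenyl in place of 4-fluorophenyl brings a number 30 percentage points higher from compound 2 to compound 3 (beyond the scatter), with the rest of the molecule unchanged. The two groups differ in more than one respect, since the entering group carries one hydrogen-bond acceptor and the leaving group none, and their names also show a different substituent at a different number on the ring, so this single pair cannot separate these differences. No measurement at hand bears on why the response changes with this swap.

Going by these compounds, it remains open whether the higher response follows the methoxy group or its number on the ring, a question that 4-methoxyphenyl, 3-fluorophenyl and plain phenyl on the same chain would help to settle. Also open, on these data alone, is how far the change can be carried, for instance to 3-ethoxyphenyl, and whether the response of compound 3 survives replacing the ethyl group on the amide nitrogen with a methyl group.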